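The source may report more compounds than this note shows. Statements on the series, on what has been measured and on what is new or still open speak of the compounds shown alone.

Working notes on the series. Compound 1 `COc1cc(/C=C/C(=O)C2=C(/C=C/c3ccc(O)c(OC)c3)NC(=S)NC2c2ccccc2)ccc1O` carries an unsubstituted phenyl on the saturated ring carbon; in a functional assay, with a stated time of 20 min, tested at 20 uM (on this read-out lower numbers stand for a weaker effect and higher numbers for a stronger effect at the one concentration tested), compound 1 gives 38%. Compound 2 `COc1cc(/C=C/C(=O)C2=C(/C=C/c3ccc(O)c(OC)c3)NC(=S)NC2c2ccccc2O)ccc1O` gives 72.3%, and compound 3 `COc1cc(/C=C/C(=O)C2=C(/C=C/c3ccc(O)c(OC)c3)NC(=S)NC2c2ccc(N(C)C)cc2)ccc1O` gives 83%, the highest of the three measured values. Compound 4 `COc1cc(/C=C/C(=O)C2=C(/C=C/c3ccc(O)c(OC)c3)NC(=S)NC2c2c(Cl)cccc2Cl)ccc1O` is not yet measured and differs from compound 3 at that same carbon: 2,6-dichlorophenyl in place of 4-(dimethylamino)phenyl on a saturated ring carbon. Of the measured steps, a number 10.7 percentage points higher from compound 2 to compound 3 (beyond the scatter) is the closest parallel, an exchange of the aryl group at that carbon, while a number 34.3 percentage points higher from compound 1 to compound 2 (beyond the scatter) and a number 45 percentage points higher from compound 1 to compound 3 (beyond the scatter) show that substituents on that ring moved the read-out far beyond the scatter. For the measured compounds named here, no chlorine-bearing analogue exists in the set, so the direction is uncertain. The expected step is a number 28 percentage points lower from compound 3 to compound 4 (beyond the scatter), a fall. Compound 4 is therefore estimated at 55%, with a range from 30% to 80%.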

Compound 4, a percentage reported as activity, at one concentration (the size of the read-out at that concentration, not a potency): 43.2%
Estimate against measurement, compound 4: 11.8 percentage points above, and the stated range covers the measured number.
By their numbers in this assay, from the lowest: compounds 1 and 4 (each within the scatter of the next); then compound 2; then compound 3.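

In this assay, a substituted aryl group at the saturated ring carbon does not by itself keep the read-out high: 2,6-dichlorophenyl gives a number 39.8 percentage points lower from compound 3 to compound 4 (beyond the scatter) and a number 29.1 percentage points lower from compound 2 to compound 4 (beyond the scatter). Against the unsubstituted phenyl the same group gives a number 5.2 percentage points higher from compound 1 to compound 4 (within the scatter), which makes it the only substituted aryl group here not separated from phenyl. No evidence on why these aryl groups differ is available.

The compounds shown leave open whether a single chlorine on that aryl ring would read like the two here. From the compounds shown here alone, how a methoxy or a carboxylic acid on that ring would read also remains open.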